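Trifluoromethyl on the benzyloxy arm across two macrocyclic cores

This account rests on a few compounds, and the source may have more. Where it says the series, first, only, none or still open, it means among the compounds named here.

Two cores appear in this series, and the difference between them is not broken down here. Compound 1 `c1ccc(COc2ccc(Nc3ncnc4cc5c(cc34)OCCOCCOCCO5)cc2)cc1` carries the larger core; in a functional assay on HepG2 cells (Homo sapiens) for antiproliferative activity, read by MTT assay, with a stated time of 72 h (on this read-out lower numbers stand for stronger inhibition and higher numbers for weaker inhibition), compound 1 reports only a limit of the assay, > 100000 nM. Compound 2 `FC(F)(F)c1ccc(COc2ccc(Nc3ncnc4cc5c(cc34)OCCOCCOCCO5)cc2)cc1` is compound 1 with the change (trifluoromethyl in place of hydrogen on an aromatic carbon); in this assay compound 2 likewise reports only a limit, > 100000 nM. The step that the two limits leave unreadable from compound 1 to compound 2 therefore cannot be sized, since both values sit at the limit of > 100000 nM in this assay, at which 2 of the 3 values shown sit, and nothing of their relative standing is readable.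

Among the compounds with values here, compound 3 `c1ccc(COc2ccc(Nc3ncnc4cc5c(cc34)OCCOCCO5)cc2)cc1` carries the smaller core and is the only compound with a number in this assay, where compound 3 gives 55500 nM. It stands as the single measured point against two limits, so no ordering among the three is claimed.

Compound 4 `FC(F)(F)c1ccc(COc2ccc(Nc3ncnc4cc5c(cc34)OCCOCCO5)cc2)cc1` is compound 3 with the change (trifluoromethyl in place of hydrogen on an aromatic carbon), the same change as from compound 1 to compound 2, made on the same place and cut the same way. Because the step that the two limits leave unreadable from compound 1 to compound 2 cannot be read, the earlier pair gives no size to carry over, and the expectation for compound 4 rests on the value of compound 3 alone, 55500 nM. A step of about a 1.3-fold higher number from compound 3 to compound 4 (0.10 log units; within the scatter) is expected, lying within the usual scatter. Compound 4 is therefore estimated at 70000 nM, with a range of 30000 nM to 160000 nM, and with a real chance that this assay reports only a limit for it.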

Compound 4, half-maximal inhibitory concentration: > 100000 nM
Compound 4: no number, only a limit; the forecaster's own chance of this, stated with the estimate: 40%; at least 1.4-fold (0.15 log units) between middle value and limit.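

In this assay, the trifluoromethyl change on the core of compound 3 reads as an at least 1.8-fold higher number from compound 3 to compound 4 (0.25 log units; that floor lies within the scatter), which is a floor and not a size, and this floor gives no firm sign of a real shift. On the core of compound 1 the same change cannot be read, so there are no two sizes to set side by side, and nothing shows that the change carries over from one core to the other, or that it fails to. All that can be said is that neither 4-(trifluoromethyl)benzyl compound, compound 2 or compound 4, yields a number, and that any comparison here is bounded by a limit of the assay: the limit of > 100000 nM in this assay, at which 3 of the 4 values shown sit.

Still open, on these data alone, is how large the step to compound 4 really is, and whether this change has a measurable size on either core. Also open, as far as these compounds go, is what an amine or a carboxylic acid in place of trifluoromethyl on the same aromatic carbon would give on these two cores, and whether either would bring a value clear of the limit.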